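From Methylpiperazine to Piperidine on the Shared Core

A few compounds are considered here, and "the series" means these few. Any claim that something is new, unique, unknown or untested is made for them only; others in the source may bear on it.

Within the data shown here, in a functional assay on NCI-H3122 cells (Homo sapiens) for antiproliferative activity, read by MTT assay, with a stated time of 48 h (a lower number here means a stronger inhibitor, a higher number a weaker inhibitor), compound 2 (`Cc1ccc(CNC(=O)c2cccc(C(C)Oc3ccnc(NN4CCN(C)CC4)c3)c2)cc1`) gives 8100 nM as the only actual number so far. Compound 1 (`Cc1ccc(CNC(=O)c2cccc(C(C)Oc3ccnc(NN4CCOCC4)c3)c2)cc1`) is recorded at > 100000 nM as a limit of the assay, not a number.

Compound 3 (`Cc1ccc(CNC(=O)c2cccc(C(C)Oc3ccnc(NN4CCCCC4)c3)c2)cc1`) shares the core of compound 2 and differs in one place: piperidin-1-yl in place of 4-methylpiperazin-1-yl on a nitrogen on an aromatic ring so that piperidin-1-yl stands in place of 4-methylpiperazin-1-yl on a nitrogen on an aromatic ring.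

Among the measured compounds shown here, only one measured step bears on this change. For the measured compounds named here, with 4-methylpiperazin-1-yl in place of morpholin-4-yl, the step reads an at least 12-fold lower number from compound 1 to compound 2 (1.09 log units; beyond the scatter) and it is the sole evidence on this position. Compound 3, like compound 1, lacks the 4-methylpiperazin-1-yl group, so losing that group is expected to give back part of that large gain. A moderate step to a higher number is therefore expected, though one step is a thin basis and compound 3 could also reach the assay limit. The expected step is a 3.1-fold higher number from compound 2 to compound 3 (0.49 log units; beyond the scatter) in this assay on this reading. For compound 3 the estimated value is 25000 nM with an expected range from 7000 nM to 90000 nM in this assay.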

Compound 3, half-maximal inhibitory concentration: 37400 nM
Beside the measured number, compound 3's estimate is 1.5-fold (0.17 log units) below it; the range from low to high includes it.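

In this assay, piperidin-1-yl in place of 4-methylpiperazin-1-yl gives a 4.6-fold higher number from compound 2 to compound 3 (0.66 log units; beyond the scatter), which shows that the 4-methylpiperazin-1-yl group of compound 2 is not interchangeable with another six-membered non-aromatic ring at this place. Piperidin-1-yl in place of morpholin-4-yl gives an at least 2.6-fold lower number from compound 1 to compound 3 (0.42 log units; beyond the scatter), so the three groups now fall into an order in which compound 3 lies between the other two, rather than the series dividing simply into a group that gives a measurable number and one that does not. The size of that second step is only a bound, since compound 1 stands at a limit of the assay and not at a number: the limit of > 100000 nM in this assay, at which 1 of the 3 values shown sits.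

The compounds shown leave open how a piperazin-1-yl ring without the methyl group, or an open-chain amine such as dimethylamino, would stand at this place, so the contributions of the second ring nitrogen and of its methyl group cannot yet be told apart. As far as these compounds go, whether the order of these three groups would hold outside this assay also stays open.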